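A methyl on the hydroxy of compound 2

The source may report more compounds than this note shows. Statements on the series, on what has been measured and on what is new or still open speak of the compounds shown alone.

Measured in a functional assay on OPM-2 cells (Homo sapiens) for inhibition, with a stated time of 24 h, in the presence of a further agent that is not named here; a lower number here means a stronger inhibitor, a higher number a weaker inhibitor:
- compound 1 `O=C1NS(=O)(=O)CC/C=C/C[C@H](O)[C@@H]2CC[C@H]2CN2C[C@@]3(CCCc4cc(Cl)ccc43)COc3ccc1cc32`: 1900 nM
- compound 2 `C[C@@H]1[C@@H](C)C/C=C/[C@@](O)(CC(=O)N(C)C)[C@@H]2CC[C@H]2CN2C[C@@]3(CCCc4cc(Cl)ccc43)COc3ccc(cc32)C(=O)NS1(=O)=O`: 52 nM

Compound 2, at 52 nM, holds the lower number of the two, and compound 1 stands at 1900 nM. The gap between these two compounds lies beyond the scatter. Compound 3 `CO[C@@]1(CC(=O)N(C)C)/C=C/C[C@H](C)[C@@H](C)S(=O)(=O)NC(=O)c2ccc3c(c2)N(C[C@@H]2CC[C@H]21)C[C@@]1(CCCc2cc(Cl)ccc21)CO3` differs from compound 2 by methyl in place of hydrogen on an oxygen on a saturated carbon. Among the compounds with values here, no measured pair shows this change. In this assay, no step beyond the scatter is expected, in either direction. The expected step is a 1.3-fold lower number from compound 2 to compound 3 (0.11 log units; within the scatter). For compound 3 the estimated value is 40 nM, with an expected range of 12 nM to 130 nM.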

Compound 3, half-maximal inhibitory concentration: 41 nM
Compound 3: the middle estimate sits 1.0-fold (0.01 log units) below what was measured; the range from low to high includes it.
By their numbers in this assay, from the lowest: compounds 3 and 2 (each within the scatter of the next); then compound 1.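

In this assay, going from hydroxy to methoxy on this oxygen gives a 1.3-fold lower number from compound 2 to compound 3 (0.10 log units; within the scatter) and so shows that the oxygen on the saturated carbon can carry a methyl in place of its hydrogen without a step beyond the scatter. The earlier compounds shown here held no change at this oxygen. No measurement here offers an explanation for this result.

From the compounds shown here alone, what remains open is whether a group larger than methyl on this oxygen, such as ethyl or a longer chain ending in an amine, would leave the number within the scatter as well.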